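The source may report more compounds than this note shows. Statements on the series, on what has been measured and on what is new or still open speak of the compounds shown alone.

Of the compounds shown here, two of one shared core have been tested in a functional assay on HeLa cells (Homo sapiens) for cytotoxicity, read by CCK-8 assay; on this read-out lower numbers stand for stronger inhibition and higher numbers for weaker inhibition. Compound 1, `Oc1ccc(-c2cc(-c3ccco3)cc(-c3ccccc3O)n2)cc1`, reaches only a limit there, and in this assay compound 1 gives > 50000 nM. Compound 2, `Oc1ccccc1-c1cc(-c2ccoc2)cc(-c2ccccc2O)n1`, likewise reaches only a limit, and in this assay compound 2 gives > 50000 nM. So compound 2 stands at the limit itself, with no number beneath it, and both values shown sit together at the limit of > 50000 nM in this assay, at which 2 of the 2 values shown sit. The unmeasured compound 3, `Oc1ccc(-c2cc(-c3ccoc3)cc(-c3ccccc3O)n2)cc1`, differs from compound 2 in one place: 4-hydroxyphenyl in place of 2-hydroxyphenyl on an aromatic carbon. Among the measured compounds shown here, no step between measured compounds exists to guide this change. Because both measured values sit at the limit of > 50000 nM in this assay, at which 2 of the 2 values shown sit, the expected step is a step that the limit leaves unreadable from compound 2 to compound 3, none beyond the scatter, and compound 3 will most likely again be reported only as a limit. Compound 3 is therefore estimated to give about 80000 nM, expected to lie between 40000 nM and 200000 nM.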

Compound 3, half-maximal inhibitory concentration: > 50000 nM
Compound 3: only a limit was reported (the forecaster's own chance of this, stated with the estimate: 85%); the middle value is on the limit's open side.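

Compound 3 also gives only a limit, so neither its step from compound 2 nor its step from compound 1 can be read: the limit of > 50000 nM in this assay, at which 3 of the 3 values shown sit.

The compounds shown leave open whether moving the hydroxyl of the hydroxyphenyl group or changing furan-2-yl to furan-3-yl alters the result at all.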